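Amine side-chain swap on the shared core

This account rests on a few compounds, and the source may have more. Where it says the series, first, only, none or still open, it means among the compounds named here.

Compound 3 `O=C1c2c[n+]([O-])c3ccccc3c2C(=O)c2c1c1ccccc1n2CCCCN1CCNCC1` carries an amine-terminated chain on the aromatic nitrogen of the shared core; in a toxicity assay on L02 cells (Homo sapiens) for cytotoxicity, read by MTT assay, with a stated time of 72 h (on this read-out lower numbers stand for stronger inhibition and higher numbers for weaker inhibition), compound 3 gives 1380 nM. This is the highest of the three numbers gathered so far. Compound 1 `O=C1c2c[n+]([O-])c3ccccc3c2C(=O)c2c1c1ccccc1n2Cc1cn([C@@H]2C[C@H](O)[C@@H](CO)O2)nn1` sits nearest, giving 630 nM in this assay, and compound 2 `CC1(C)OCC(Cn2cc(Cn3c4c(c5ccccc53)C(=O)c3c[n+]([O-])c5ccccc5c3C4=O)nn2)O1` lies furthest, at 120 nM in this assay. Going by the values given here, the one step that can be read directly, a 5.3-fold lower number from compound 1 to compound 2 (0.72 log units; beyond the scatter), concerns an exchange of oxolanyl for dioxolanylmethyl groups on an aromatic nitrogen and not the amine chain, so it does not bear on the change now considered.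

Compound 4 `O=C1c2c[n+]([O-])c3ccccc3c2C(=O)c2c1c1ccccc1n2CCCN1CCC(O)CC1` differs from compound 3 in one place: 4-hydroxypiperidin-1-yl in place of (piperazin-1-yl)methyl on a saturated chain carbon, three bonds along the chain from an aromatic nitrogen. Among the compounds with values here, no measured pair tests an exchange of this kind at this position, so nothing supports a directed expectation. The values of compound 2 and compound 3 in this assay show only that edits away from the core can move the number. The working expectation is therefore a step of a 1.3-fold lower number from compound 3 to compound 4 (0.10 log units; within the scatter), within the scatter. Compound 4 is estimated at 1100 nM in this assay, with a range from 450 nM to 2700 nM.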

Compound 4, half-maximal inhibitory concentration: 120 nM
Estimate against measurement, compound 4: 9.2-fold (0.96 log units) above; measured number outside the range, below it.
By their numbers in this assay, from the lowest: compounds 2 and 4 (each within the scatter of the next); then compound 1; then compound 3.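

In this assay, going by these compounds alone, this position proves sensitive to the exchange, with a 12-fold lower number from compound 3 to compound 4 (1.06 log units; beyond the scatter), a step rated large, whereas the one earlier step, a 5.3-fold lower number from compound 1 to compound 2 (0.72 log units; beyond the scatter), concerned a different group on the aromatic nitrogen and was rated modest. The groups that leave and enter match in heavy atoms, hydrogen-bond donors and hydrogen-bond acceptors, so those counts do not track the step; what differs is the atom make-up and the ring, and cut one bond further out, the same difference reads 4-(piperazin-1-yl)butyl to 3-(4-hydroxypiperidin-1-yl)propyl, so chain and ring change together. No measurement on hand accounts for the size of this step.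

The compounds shown leave open whether the chain or the ring carries the step, since no compound varies one with the other held fixed; a 3-(piperazin-1-yl)propyl chain on the aromatic nitrogen of the shared core would separate the two. Also open, on these data alone, is what the hydroxyl contributes, which an unsubstituted piperidin-1-yl group at the end of the same propyl chain would address.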